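Methylating the amine of a melanocortin receptor 4 ligand

This account rests on a few compounds, and the source may have more. Where it says the series, first, only, none or still open, it means among the compounds named here.

Compound 1 `CC[C@H](C)C(N)c1cc(C(F)(F)F)ccc1N1CCN(C(=O)CCc2ccc(Cl)cc2Cl)CC1` is the strongest binder among the three measured compounds in an assay on HEK293 cells for displacement of a labelled ligand from Melanocortin receptor 4 (Homo sapiens) (a lower number here means a stronger inhibitor, a higher number a weaker inhibitor), where compound 1 gives 75 nM. Compound 2 `CC(C)C[C@H](N)c1cc(C(F)(F)F)ccc1N1CCN(C(=O)CCc2ccc(S(C)(=O)=O)cc2)CC1` gives 4900 nM in this assay, and compound 3 `CC(C)C[C@H](N)c1cc(C(F)(F)F)ccc1N1CCN(C(=O)CCc2csc3ccccc23)CC1` gives 2300 nM, both far above compound 1. Going by the values given here, the one single-change step measured, a 2.1-fold lower number from compound 2 to compound 3 (0.33 log units; beyond the scatter), concerns the tail on the amide side of the shared core, not the aminoalkyl group, so it does not bear on the change considered here.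

Compound 4 `CN[C@@H](CC(C)C)c1cc(C(F)(F)F)ccc1N1CCN(C(=O)CCc2ccc(Cl)cc2Cl)CC1` differs from compound 1 in that aminoalkyl group: 3-methyl-1-(methylamino)butyl in place of 1-amino-2-methylbutyl on an aromatic carbon. Nothing measured here isolates the effect of adding a methyl to the amine or of moving the methyl branch along the short chain, and the gap between compound 1 and compounds 2 and 3 mixes that chain difference with a different amide tail, so it cannot be read as a guide. Among the compounds with values here, with no bearing step, the expectation for compound 4 is a number close to compound 1, with wide uncertainty and no preferred direction beyond the scatter, expressed as a 2.0-fold higher number from compound 1 to compound 4 (0.30 log units; within the scatter). Compound 4 is therefore estimated at 150 nM, within a range from 30 nM to 800 nM.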

Compound 4, inhibition constant: 1900 nM
Beside the measured number, compound 4's estimate is 13-fold (1.10 log units) below it; measured number outside the range, above it.
By their numbers in this assay, from the lowest: compound 1; then compounds 4 and 3 (each within the scatter of the next); then compound 2.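

With the amide tail and the rest of the shared core held the same, the aminoalkyl group on the aromatic carbon proves to matter greatly in this assay: a 25-fold higher number from compound 1 to compound 4 (1.40 log units; beyond the scatter). Going by these compounds alone, the only earlier step concerned the amide tail, so this is the first direct sign that this position is sensitive, and the change in size is small: a group of 6 heavy atoms gives way to one of 7, each with 1 hydrogen-bond donor and 1 hydrogen-bond acceptor. No measurement at hand accounts for why the number rises so far.

Going by these compounds, this step makes two changes at once, a methyl added to the amine and the methyl branch moved along the chain, so the share of each stays open; the 1-amino-3-methylbutyl group, seen here only with other amide tails in compound 2 and compound 3, would separate them if paired with the amide tail of compound 1. Also open, on these data alone, is how this position responds to other amines at the same carbon, such as an ethylamine or a dimethylamine, on either chain.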